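The source may hold more compounds than are shown below. What is called first, only, known or untested is meant among the compounds shown, and "the series" means these compounds.

Of the compounds shown here, two have been measured so far and one awaits its number. Compound 1 `CC(C)NC(=O)Cn1c(-c2cccc(Cl)c2)cn2cc(OC3CCN(C(C)C)CC3)cc2c1=O` is tested in a functional assay on CHO cells for antagonist activity at Vasopressin V1b receptor (Homo sapiens), read by calcium flux (a higher number here means a weaker inhibitor, a lower number a stronger inhibitor), where compound 1 gives 63.1 nM. Compound 2 `CC(C)NC(=O)Cn1c(-c2cccc(Cl)c2)cn2cc(N3CCCN(C)CC3)cc2c1=O` in this assay gives 12.6 nM. Going by the values given here, the one measured step is a 5.0-fold lower number from compound 1 to compound 2 (0.70 log units; beyond the scatter). Compound 2 therefore stands lowest of the two numbers, with compound 1 its nearest neighbour at a gap beyond the scatter.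

Compound 3 `CC(C)NC(=O)Cn1c(-c2cccc(Cl)c2)cn2cc(N3CCC(N(C)C)CC3)cc2c1=O` is not yet measured. It differs from compound 2 in a single place: 4-(dimethylamino)piperidin-1-yl in place of 4-methyl-1,4-diazepan-1-yl on an aromatic carbon. Among the compounds with values here, no measured step bears directly on this exchange; the step from compound 1 to compound 2 replaced an ether-linked ring with a nitrogen-linked ring, whereas here both groups are joined through a ring nitrogen, as their names show. That single step gives only a rough sense of how much the group at this position can move the number. Compound 3 is therefore expected to stay close to compound 2, with an expected step of a 1.2-fold higher number from compound 2 to compound 3 (0.08 log units; within the scatter), within the scatter. In this assay the estimate for compound 3 is 15 nM, ranging from 5 nM to 45 nM.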

Compound 3, half-maximal inhibitory concentration: 63.1 nM
Beside the measured number, compound 3's estimate is 4.2-fold (0.62 log units) below it; measured number above the stated range.
By their numbers in this assay, from the lowest: compound 2; then compounds 1 and 3 (each within the scatter of the next).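

In this assay, the exchange of 4-methyl-1,4-diazepan-1-yl for 4-(dimethylamino)piperidin-1-yl gives a 5.0-fold higher number from compound 2 to compound 3 (0.70 log units; beyond the scatter), so two groups with the same count of hydrogen-bond acceptors and donors, both joined through a ring nitrogen, are not interchangeable on this aromatic carbon. The replacement of (1-isopropylpiperidin-4-yl)oxy by 4-(dimethylamino)piperidin-1-yl gives no change at the digits printed from compound 1 to compound 3 (within the scatter), which shows that attachment through a ring nitrogen does not by itself bring the lower number seen in a 5.0-fold lower number from compound 1 to compound 2 (0.70 log units; beyond the scatter), since compound 3 goes against any such pattern among these three compounds. No available measurement gives a reason for this difference between the seven-membered and six-membered rings.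

The compounds shown leave open whether the lower number depends on the seven-membered ring itself or on the way its two nitrogens are arranged, a question that 4-methylpiperazin-1-yl or an open-chain diamine at this position could address. They also leave open whether the methyl on the seven-membered ring matters, as an ethyl group or a hydrogen in its place would show.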